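Swapping an amine substituent for an amide on a thiazole core

A few compounds are considered here, and "the series" means these few. Any claim that something is new, unique, unknown or untested is made for them only; others in the source may bear on it.

Of the compounds shown here, three share a common core and have been tested in an ADME assay on HepG2 2.2.15 cells (Homo sapiens) for cytotoxicity; a lower number here means that less compound is tolerated, a higher number that more compound is tolerated. Compound 1 `Cc1cc(C(C)C)ccc1OC(c1ccc(Cl)cc1)c1cnc(NC(=O)OC(C)(C)C)s1` carries a tert-butyl carbamate on the ring nitrogen. In this assay compound 1 reaches only a limit, > 50000 nM, which is not a number. Compound 2 `O=C(Nc1ncc(C(OCc2ccc(Br)cc2)c2ccccc2)s1)c1cccs1`, an amide of a thiophene acid, is recorded in this assay as "not toxic" (no number reported). Compound 3 `Clc1ccc(C(Oc2ccc3cc(Br)ccc3c2)c2cnc(NCC3CCCCC3)s2)cc1`, which bears a cyclohexylmethyl group on the ring nitrogen, is likewise recorded in this assay as "not toxic" (no number reported), so no single number places it among the others; it stands with the two entries that show no measurable cytotoxicity.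

Compound 4 `O=C(Nc1ncc(C(Oc2ccc3cc(Br)ccc3c2)c2ccc(Cl)cc2)s1)c1ccccc1` differs from compound 3 in one place: benzoyl in place of cyclohexylmethyl on a nitrogen on an aromatic ring. Going by the values given here, no measured step between compounds exists here, so the expected step size is none beyond the scatter, and since the limit of > 50000 nM in this assay, at which 1 of the 3 values shown sits, marks where the only numeric entry sits, compound 4 is expected most likely to report a limit as well. The estimated value for compound 4 in this assay is 50000 nM, within 20000 nM to 100000 nM.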

Compound 4, half-maximal cytotoxic concentration: "not toxic" (no number reported)
The entry for compound 4 holds no number, and the estimate cannot be compared.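

Compound 3 and compound 4 are both recorded in this assay as "not toxic" without a number, so no step can be read for benzoyl in place of cyclohexylmethyl. The compounds shown leave open how much of each compound these cells tolerate, since the only entry with a figure is a limit: the limit of > 50000 nM in this assay, at which 1 of the 4 values shown sits.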